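The source may report more compounds than this note shows. Statements on the series, on what has been measured and on what is new or still open speak of the compounds shown alone.

Working notes on the series. Compound 1 `Cc1noc(C)c1-c1cnc(N)c(Oc2ccc(C(=O)NC3CCCCC3)cc2)n1` gives 40400 nM in a functional assay on U-87MG ATCC cells for inhibition, with U-87 MG (Homo sapiens) as the target, read by MTT assay, with a stated time of 72 h; on this read-out lower numbers stand for stronger inhibition and higher numbers for weaker inhibition. Going by the values given here, compound 2 `Cc1noc(C)c1-c1cnc(N)c(Oc2ccc(C(=O)Nc3ccccc3Cl)cc2)n1` gives 60500 nM in this assay, and the only single-point step measured so far, a 1.5-fold higher number from compound 1 to compound 2 (0.18 log units; within the scatter), concerns the group on the amide nitrogen. Compound 3 `Cc1noc(C)c1-c1cnc(N)c(NCc2ccc(C(=O)Nc3ccc(Cl)cc3)cc2)n1` carries a different linkage between the shared core and the amide portion, and in this assay compound 3 reaches only > 100000 nM, which is a limit of the assay and not a number. From the compounds shown here alone, compound 3 therefore stands at the limit of > 100000 nM in this assay, at which 1 of the 3 values shown sits, and how far beyond that bound its true value lies is unknown.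

Compound 4 `Cn1cc(-c2cnc(N)c(NCc3ccc(C(=O)Nc4ccc(Cl)cc4)cc3)n2)cn1` differs from compound 3 by 1-methyl-1H-pyrazol-4-yl in place of 3,5-dimethyl-1,2-oxazol-4-yl on an aromatic carbon. Among the compounds with values here, no measured step touches this five-membered heteroaryl; the one measured step, a 1.5-fold higher number from compound 1 to compound 2 (0.18 log units; within the scatter), changed another part of the molecule and lay within the scatter, so it does not bear on the present change. Within the data shown here, with compound 3 at a limit and no comparable step available, no direction can be derived, and the step expected in this assay is none beyond the scatter, most likely with compound 4 sitting again at the limit. The estimated value for compound 4 is 100000 nM, expected between 30000 nM and 300000 nM. The step this expectation implies is a number no higher from compound 3 to compound 4 (the limit leaves the size open).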

Compound 4, half-maximal inhibitory concentration: > 100000 nM
Compound 4 ended at the assay's limit; the forecaster's own chance of this, stated with the estimate: 60%; the middle value sits exactly at the limit.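

In this assay compound 4 gives > 100000 nM, a limit of the assay and not a number, and compound 3 also stands at a limit, so no step can be read between compound 3 and compound 4: the limit of > 100000 nM in this assay, at which 2 of the 4 values shown sit.

The compounds shown leave open how far past the limit either true value lies, and whether 1-methyl-1H-pyrazol-4-yl in place of 3,5-dimethyl-1,2-oxazol-4-yl makes any difference in this series.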